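The source may hold more compounds than are shown below. What is called first, only, known or untested is meant among the compounds shown, and "the series" means these compounds.

Measured compounds:
Compound 1 `N#Cc1ccc(Nc2nccc(Oc3ccc(-c4ccc(C#N)cc4)c(F)c3)n2)cc1`: > 307000 nM
Compound 2 `N#Cc1ccc(Nc2nccc(Nc3ccc(-c4ccc(C#N)cc4)c(F)c3)n2)cc1`: > 271000 nM
Compound 3 `Cc1cc(Oc2ccnc(Nc3ccc(C#N)cc3)n2)ccc1-c1ccc(C#N)cc1`: 29400 nM

Three compounds were run in a functional assay on MT4 cells (Homo sapiens) for cytotoxicity, read by MTT assay, with a stated time of 5 days; a higher number here means that more compound is tolerated, a lower number that less compound is tolerated. Compound 1 `N#Cc1ccc(Nc2nccc(Oc3ccc(-c4ccc(C#N)cc4)c(F)c3)n2)cc1` gives only a limit of the assay, > 307000 nM. Compound 2 `N#Cc1ccc(Nc2nccc(Nc3ccc(-c4ccc(C#N)cc4)c(F)c3)n2)cc1` likewise gives only a limit, > 271000 nM. Compound 3 `Cc1cc(Oc2ccnc(Nc3ccc(C#N)cc3)n2)ccc1-c1ccc(C#N)cc1` gives a number, 29400 nM. The difference between the core of compound 1 and the core of compound 2 is not broken down here.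

Compound 3 differs from compound 1 in one place: methyl in place of fluoro on an aromatic carbon. This change made an at least 10-fold lower number from compound 1 to compound 3 (1.01 log units; beyond the scatter). Because compound 1 sits at the limit of > 307000 nM in this assay, at which 1 of the 3 values shown sits, the true size of that step is known only as a floor; the gap may be larger.

Compound 4 `Cc1cc(Nc2ccnc(Nc3ccc(C#N)cc3)n2)ccc1-c1ccc(C#N)cc1` has not yet been measured in this assay. It differs from compound 2 by the same change: methyl in place of fluoro on an aromatic carbon. Since compound 2 sits at the limit of > 271000 nM in this assay, at which 1 of the 3 values shown sits, the starting point for compound 4 is likewise only a floor, and the step from compound 2 to compound 4 cannot be fixed closely. Compound 4 is expected to land near the number given by compound 3, 29400 nM, since the same change carried compound 1 to compound 3 by an at least 10-fold lower number from compound 1 to compound 3 (1.01 log units; beyond the scatter). The expected step is therefore an at least 6.7-fold lower number from compound 2 to compound 4 (0.83 log units; beyond the scatter), and it is an estimate. For compound 4 the estimated value is 40000 nM, with a plausible range from 12000 nM to 250000 nM.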

Compound 4, half-maximal cytotoxic concentration: 12400 nM
Estimate against measurement, compound 4: 3.2-fold (0.51 log units) above, within the range that was stated.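

In this assay, methyl in place of fluoro on an aromatic carbon, ortho to a 4-cyanophenyl group, gave an at least 21-fold lower number from compound 2 to compound 4 (1.33 log units; beyond the scatter), which shows that on these two cores the same change moves the number in the same direction, toward less compound tolerated. Set side by side, the two steps agree in direction but cannot be compared in size: the same change on two cores in this assay, an at least 10-fold lower number (1.01 log units; beyond the scatter) from compound 1 to compound 3 and an at least 21-fold lower number (1.33 log units; beyond the scatter) from compound 2 to compound 4; the limit leaves it open whether they differ Compound 2 gives only a limit and no number, so the new step is known only as a floor, and the data do not show that the change has the same size on both cores, nor that it would carry to any core beyond these two: the limit of > 271000 nM in this assay, at which 1 of the 4 values shown sits.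

The compounds shown leave open whether the step is particular to methyl or would also appear with other groups on that carbon, such as chloro, methoxy or a longer chain like ethyl. They also leave open how the same change would behave on a third core, and whether a compound with plain hydrogen on that carbon would sit nearer the fluoro compounds or the methyl compounds.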